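This account rests on a few compounds, and the source may have more. Where it says the series, first, only, none or still open, it means among the compounds named here.

Measured in a functional assay on MCF7 cells (Homo sapiens) for antiproliferative activity, read by luminescence, with a stated time of 24 h; a lower number here means a stronger inhibitor, a higher number a weaker inhibitor:
- compound 1 `CC(=O)NCCNC(=O)CCC(=O)Oc1c(C)c(C)c2c(c1C)CCC(C)(COc1ccc(/C=C3\SC(=O)NC3=O)cc1)O2`: > 50000 nM
- compound 2 `Cc1c(C)c2c(c(C)c1O)CCC(C)(COc1ccc(/C=C3\SC(=O)NC3=O)cc1)O2`: 29700 nM

The entry for compound 1 is a limit of the assay and not a number. Among the compounds with values here, that leaves compound 2, at 29700 nM, as the only true number in this assay.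

Compound 3 `Cc1c(C)c2c(c(C)c1OC(=O)OC(C)(C)C)CCC(C)(COc1ccc(/C=C3\SC(=O)NC3=O)cc1)O2` differs from compound 2 by tert-butoxycarbonyl in place of hydrogen on an oxygen on an aromatic ring, with tert-butoxycarbonyl in place of hydrogen on an oxygen on an aromatic ring. Within the data shown here, no measured step shows what this change does. A small move toward weaker inhibition in this assay is expected, perhaps none beyond the usual scatter, and the assay may report only a limit. The expected change is a 1.3-fold higher number from compound 2 to compound 3 (0.13 log units; within the scatter). Compound 3 is estimated at 40000 nM, within a range of 15000 nM to 90000 nM.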

Compound 3, half-maximal inhibitory concentration: 7700 nM
Compound 3: the middle estimate sits 5.2-fold (0.72 log units) above what was measured; the measured number lies below the stated range.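

In this assay, tert-butoxycarbonyl in place of hydrogen on the oxygen on the aromatic ring gives a 3.9-fold lower number from compound 2 to compound 3 (0.59 log units; beyond the scatter) and shows that a free hydroxy is not needed there for this activity. On the carbonyl carbon, tert-butoxy in place of 2-((2-acetamidoethyl)carbamoyl)ethyl gives an at least 6.4-fold lower number from compound 1 to compound 3 (0.81 log units; beyond the scatter) as a step that rests on a limit for compound 1, not on a number: the limit of > 50000 nM in this assay, at which 1 of the 3 values shown sits.

As far as these compounds go, it remains open whether a smaller group on this oxygen, such as acetyl or methyl, would do the same. From the compounds shown here alone, a chain ending in an amine or a carboxylic acid also remains open.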